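Replacing Heptyl with Hept-1-yn-1-yl on a Saturated Ring Carbon

The source may report more compounds than this note shows. Statements on the series, on what has been measured and on what is new or still open speak of the compounds shown alone.

Of the compounds shown here, two have measured values so far. In a functional assay on L1210 cells (Mus musculus) for inhibition (on this read-out lower numbers stand for stronger inhibition and higher numbers for weaker inhibition), compound 1 (`CCCCCCC[C@H]1O[C@@H]2OC(=O)N(C(=O)CCl)[C@@H]2CC1=O`) gives 96000 nM. In this assay compound 2 (`CCCCCCC[C@@]1(C)O[C@@H]2OC(=O)N(C(=O)CCl)[C@@H]2CC1=O`) gives 28000 nM, the lower of the two numbers, and the gap between them lies beyond the scatter. Compound 3 (`CCCCCC#C[C@@]1(C)O[C@@H]2OC(=O)N(C(=O)CCl)[C@@H]2CC1=O`) has not yet been measured. It differs from compound 2 in one place: hept-1-yn-1-yl in place of heptyl on a saturated ring carbon. Hept-1-yn-1-yl stands in place of heptyl on a saturated ring carbon, next to the ring oxygen. For the measured compounds named here, no measured pair changes this chain alone, so the data offer no direct guide to the size of the step. The estimated 1.3-fold lower number from compound 2 to compound 3 (0.10 log units; within the scatter) in this assay is small, leaning slightly towards a lower number, and is not expected to pass beyond the scatter. For compound 3 the expected value is 22000 nM, with an estimated range of 7000 nM to 65000 nM.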

Compound 3, half-maximal inhibitory concentration: 31000 nM
Compound 3: middle estimate off by 1.4-fold (0.15 log units), on the low side; the range from low to high includes it.
By their numbers in this assay, from the lowest: compounds 2 and 3 (each within the scatter of the next); then compound 1.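

In this assay, the exchange of heptyl for hept-1-yn-1-yl on this saturated ring carbon amounts to a 1.1-fold higher number from compound 2 to compound 3 (0.04 log units; within the scatter), so on this read-out the two chains cannot be told apart. For these two compounds, then, placing a triple bond in a chain of the same carbon count at this position leaves the number within the scatter. This is the first measured step at this position that changes the chain alone, and nothing shown gives a reason for the outcome. Going by these compounds, what a shorter chain, a longer chain or a chain ending in an amine or a carboxylic acid would do at this carbon remains open. Also open, on these data alone, is whether hept-1-yn-1-yl would behave in the same way on the core of compound 1, which lacks the methyl group of compound 2.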